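Replacing the 4-nitrophenyl group of compound 1

A few compounds are considered here, and "the series" means these few. Any claim that something is new, unique, unknown or untested is made for them only; others in the source may bear on it.

- compound 1 `O=C(/C=C/c1ccc([N+](=O)[O-])cc1)Nc1cc2c(Nc3ccc(F)c(Cl)c3)ncnc2cc1O[C@H]1CCOC1` gives 12000 nM
- compound 2 `COc1ccc(/C=C/C(=O)Nc2cc3c(Nc4ccc(F)c(Cl)c4)ncnc3cc2OC)cc1` gives "not active" (no number reported)

Within the data shown here, compound 1 at 12000 nM is the only compound with a number in a functional assay on A549 cells (Homo sapiens) for cytotoxicity, read by MTT assay, with a stated time of 72 h (a lower number here means a stronger inhibitor, a higher number a weaker inhibitor), and has no numerical comparator. Compound 3 `COc1ccc(/C=C/C(=O)Nc2cc3c(Nc4ccc(F)c(Cl)c4)ncnc3cc2O[C@H]2CCOC2)c(OC)c1OC` keeps the rest of compound 1 but carries 2,3,4-trimethoxyphenyl in place of 4-nitrophenyl on a double-bonded chain carbon bound to a double-bonded chain carbon and awaits testing. Among the measured compounds shown here, no measured pair isolates this change. Compound 2 at "not active" (no number reported) also has methoxy on its aryl group, which tilts the expectation slightly toward weaker inhibition. The expected change in this assay is small, an estimated 1.3-fold higher number from compound 1 to compound 3 (0.12 log units; within the scatter) in that direction. For compound 3 the expected value is 16000 nM within an estimated range of 5000 nM to 50000 nM in this assay.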

Compound 3, half-maximal inhibitory concentration: 70 nM
Estimate against measurement, compound 3: 230-fold (2.36 log units) above; the measured number lies below the stated range.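

In this assay the aryl group on this chain carbon strongly influences the number: 2,3,4-trimethoxyphenyl in place of 4-nitrophenyl gives a 170-fold lower number from compound 1 to compound 3 (2.23 log units; beyond the scatter) with the rest of the molecule unchanged. Among these compounds, this is the first step read at this position, and it shows that the position is far from indifferent to the group it carries. No measurement shown accounts for the size of this step. The compounds shown leave open which of the methoxy groups matter for this gain. They also leave open how an amine or a carboxylic acid on the aryl ring would fare here.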